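The compounds below may be only part of what the source reports. "The series", "measured", "known", "first", "only" and "open" are said of these compounds alone.

Measured compounds: compound 1 `O=C(NCc1ccc(S(=O)(=O)c2ccccc2)cc1)N1Cc2cccnc2C1` gives 144000 nM in a physicochemical assay for solubility, in phosphate buffer, with a stated time of 24 h, at pH 7.4, tested at 100 uM; on this read-out higher numbers stand for higher solubility and lower numbers for lower solubility; compound 2 `O=C(NCc1ccc(S(=O)(=O)C2CCC(F)(F)CC2)cc1)N1Cc2ccncc2C1` gives 35000 nM; compound 3 `CC(=O)N1CCC(S(=O)(=O)c2ccc(CNC(=O)N3Cc4ccncc4C3)cc2)CC1` gives 187000 nM.

Compound 3 has the highest number of the three, though its gap to compound 1 lies within the scatter, while compound 2 sits well lower. Among the compounds with values here, the one counted step, a 5.3-fold higher number from compound 2 to compound 3 (0.73 log units; beyond the scatter), changed the group on the sulfonyl sulfur and brought a modest gain. Compound 4 `O=C(NCc1ccc(S(=O)(=O)N2CCC(N3CCCC3)CC2)cc1)N1Cc2ccncc2C1` changes that same position again: 4-(pyrrolidin-1-yl)piperidin-1-yl in place of 1-acetylpiperidin-4-yl on a sulfonyl sulfur. Within the data shown here, no measured pair mirrors this exchange, so the single step offers only loose guidance; a small rise or no change beyond the scatter seems most likely. Compound 4 is therefore expected to give about 220000 nM, within 90000 nM to 500000 nM, an estimated step of a 1.2-fold higher number from compound 3 to compound 4 (0.07 log units; within the scatter).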

Compound 4, solubility: 6200 nM
Beside the measured number, compound 4's estimate is 35-fold (1.55 log units) above it; the measured number lies below the stated range.
By their numbers in this assay, from the lowest: compound 4; then compound 2; then compounds 1 and 3 (each within the scatter of the next).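

In this assay, within the data shown here, the group on the sulfonyl sulfur can move the number much further than the earlier compounds showed: the change to 4-(pyrrolidin-1-yl)piperidin-1-yl gives a 30-fold lower number from compound 3 to compound 4 (1.48 log units; beyond the scatter), a large step where the earlier one was modest. The same group also falls short of 4,4-difluorocyclohexyl, with a 5.6-fold lower number from compound 2 to compound 4 (0.75 log units; beyond the scatter), so the lowest earlier number did not mark the low end at this position. Nothing available here bears on the reason for this drop. Still open, on these data alone, is whether the pyrrolidin-1-yl ring alone carries the drop, or whether a plain piperidin-1-yl or a morpholin-4-yl on the sulfonyl sulfur would fall as far.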